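The source may report more compounds than this note shows. Statements on the series, on what has been measured and on what is new or still open speak of the compounds shown alone.

Compound 1, `Cc1nn(C)c2nc(C3CC3)c(/C=C/[C@@H](O)C[C@@H](O)CC(=O)O)c(-c3ccc(F)cc3)c12`: 35.5%
Compound 2, `CC(C)c1nc2c(c(-c3ccccc3)nn2C)c(-c2ccc(F)cc2)c1/C=C/[C@@H](O)C[C@@H](O)CC(=O)O`: 37%
Compound 3, `CC(C)c1nc2c(c(C3CC3)nn2C)c(-c2ccc(F)cc2)c1/C=C/[C@@H](O)C[C@@H](O)CC(=O)O`: 42.9%

All three were tested in an in vivo functional assay on the whole organism for inhibition of 3-hydroxy-3-methylglutaryl-coenzyme A reductase (Rattus norvegicus), at a dose of 0.2 mg/kg by the oral route; a lower number here means a weaker effect, a higher number a stronger effect of the compound at the dose given. Compound 2 stands second highest of the three numbers, but its neighbours are close: compound 1 lies only slightly lower and compound 3 only slightly higher, both gaps within the usual scatter, so the three compounds cannot be told apart on these data.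

Compound 4, `Cn1nc(-c2ccccc2)c2c(-c3ccc(F)cc3)c(/C=C/[C@@H](O)C[C@@H](O)CC(=O)O)c(C3CC3)nc21`, has not yet been measured. It differs from compound 2 in one place: cyclopropyl in place of isopropyl on an aromatic carbon.

Within the data shown here, only one measured step exists among the three compounds, a number 5.9 percentage points higher from compound 2 to compound 3 (within the scatter), and it concerns a different group at a different position, so it says little about the present change. Compound 1 also carries a cyclopropyl group at the position in question, but it differs from compound 4 in a second place as well, so only its value and that of compound 2 can be compared, and they lie within the scatter of each other. Nothing here points to a shift beyond the scatter. For compound 4 the expected result in this assay is therefore 38%, with a likely range from 27% to 49%. The expected step is a number 1 percentage points higher from compound 2 to compound 4 (within the scatter).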

Compound 4, a percentage reported as inhibition, in the whole organism at one dose (the size of the read-out at that dose, not a potency): -54.4%
Compound 4: middle estimate off by 92.4 percentage points, on the high side; measured number below the stated range.
By their numbers in this assay, from the lowest: compound 4; then compounds 1, 2 and 3 (each within the scatter of the next).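

In this assay, among these compounds, putting cyclopropyl in place of isopropyl on the aromatic carbon ortho to the 6-carboxy-3,5-dihydroxyhex-1-en-1-yl group gives a number 91.4 percentage points lower from compound 2 to compound 4 (beyond the scatter) even though both groups hold the same number of carbons, so this place is far less forgiving than the earlier compounds suggested. The other one-place comparison, phenyl in place of methyl, gives a number 89.9 percentage points lower from compound 1 to compound 4 (beyond the scatter) and shows that cyclopropyl at this place does not bring the low number by itself: compound 1 carries it alongside a methyl group, and among these four compounds the drop appears only in compound 4, where cyclopropyl and phenyl occur together. The read-out of compound 4 is also the only one of the four on the negative side of zero, so this is more than a simple loss of the effect seen in the other compounds. Going by these compounds, it remains open whether an ethyl or a tert-butyl group at this place, alongside the phenyl, would keep the number of compound 2 or fall like compound 4. What lies behind the drop also stays open, as no measurement here bears on it.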